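The source may hold more compounds than are shown below. What is called first, only, known or untested is meant among the compounds shown, and "the series" means these compounds.

In a functional assay on MCF7 cells (Homo sapiens) for antiproliferative activity, read by sulforhodamine B assay, with a stated time of 3 days (a higher number here means a weaker inhibitor, a lower number a stronger inhibitor), compound 1 (`c1ccc(Oc2ncnc3[nH]cnc23)cc1`) gives 28400 nM, compound 2 (`C=CCOc1ncnc2[nH]cnc12`) gives 44700 nM, and compound 3 (`c1ccc(Sc2ncnc3[nH]cnc23)cc1`) gives 31000 nM. Compound 3 lies within the scatter of both other compounds, so these numbers set no order among the three. Compound 4 (`Fc1ccc(Sc2ncnc3[nH]cnc23)cc1`) differs from compound 3 by one substitution, with fluoro in place of hydrogen on an aromatic carbon of a six-membered aromatic ring of carbon only, para to a large group: fluoro in place of hydrogen on an aromatic carbon. Within the data shown here, no measured pair shows the effect of such a change, so the expectation can start only from compound 3 at 31000 nM. No step beyond the scatter is expected in this assay, and neither direction is favoured. The estimated change is a 1.1-fold lower number from compound 3 to compound 4 (0.04 log units; within the scatter), which is expected to remain small. For compound 4 the estimated value is 28000 nM, with an expected range from 14000 nM to 55000 nM.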

Compound 4, half-maximal inhibitory concentration: 31600 nM
Beside the measured number, compound 4's estimate is 1.1-fold (0.05 log units) below it; the measured number falls inside the stated range.
By their numbers in this assay, from the lowest: compounds 1, 3, 4 and 2 (each within the scatter of the next).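

In this assay, compound 3 and compound 4 form the only pair shown that differs in one place, and fluoro in place of hydrogen on an aromatic carbon, para to a large group, gives a 1.0-fold higher number from compound 3 to compound 4 (0.01 log units; within the scatter). The earlier compounds shown here offered no reading of any single change, whereas this pair shows that this one substitution at this position produces no step beyond the scatter. No measurement available here accounts for this result.

The compounds shown leave open whether another group at the same position, such as chloro, trifluoromethyl, methoxy, an amine or a carboxylic acid, would give a step beyond the scatter. They also leave open whether fluoro at another place on the same ring would do so.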